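Propyl in place of cyano on the amide aryl ring

The compounds below may be only part of what the source reports. "The series", "measured", "known", "first", "only" and "open" are said of these compounds alone.

Compound 1, `COc1cccc(C(=O)Nc2cccc(-c3oc4cc(-c5ccc(F)cc5)ccc4c(=O)c3O)c2)c1`, gives 12500 nM in a functional assay on GTL 16 cells for antiproliferative activity against GTL 16 cell line (Homo sapiens), read by CCK-8 assay, with a stated time of 72 h; on this read-out lower numbers stand for stronger inhibition and higher numbers for weaker inhibition.
Compound 2, `O=C(Nc1cccc(-c2oc3cc(-c4ccc(F)cc4)ccc3c(=O)c2O)c1)c1ccc(Cl)nc1`, gives 7520 nM in this assay.
Compound 3, `N#Cc1ccc(C(=O)Nc2cccc(-c3oc4cc(-c5ccc(F)cc5)ccc4c(=O)c3O)c2)cc1`, gives 31800 nM in this assay.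

Among these three, compound 3 stands at the highest number: the step of a 2.5-fold higher number from compound 1 to compound 3 (0.41 log units; beyond the scatter) and the step of a 4.2-fold higher number from compound 2 to compound 3 (0.63 log units; beyond the scatter) both lie beyond the scatter, so compound 3 is the least active of the three on this read-out, while compound 1 and compound 2 sit within the scatter of each other, as a 1.7-fold lower number from compound 1 to compound 2 (0.22 log units; within the scatter) shows.

Compound 4, `CCCc1ccc(C(=O)Nc2cccc(-c3oc4cc(-c5ccc(F)cc5)ccc4c(=O)c3O)c2)cc1`, is the unmeasured partner of compound 3. The difference is propyl in place of cyano on an aromatic carbon. Among the measured compounds shown here, no measured step exchanges the cyano for a propyl, so the only guidance is indirect: the two steps that introduce the cyanophenyl, a 2.5-fold higher number from compound 1 to compound 3 (0.41 log units; beyond the scatter) and a 4.2-fold higher number from compound 2 to compound 3 (0.63 log units; beyond the scatter), both raised the number by a modest amount, and compound 4 removes that cyano again in favour of a propyl. Compound 4 is therefore expected to give a lower number than compound 3, a step of roughly a 2.7-fold lower number from compound 3 to compound 4 (0.42 log units; beyond the scatter), and its estimated value in this assay is 12000 nM, with a plausible range from 4500 nM to 32000 nM.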

Compound 4, half-maximal inhibitory concentration: 20400 nM
Compound 4: the middle estimate sits 1.7-fold (0.23 log units) below what was measured; the measured number falls inside the stated range.
By their numbers in this assay, from the lowest: compounds 2, 1, 4 and 3 (each within the scatter of the next, the first and the last beyond it).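

In this assay, putting propyl in place of cyano on this aromatic carbon, para to a large group, gives a 1.6-fold lower number from compound 3 to compound 4 (0.19 log units; within the scatter), so the two groups cannot be told apart here, although only cyano carries a triple bond and a hydrogen-bond acceptor. The earlier gap between the 3-methoxyphenyl and 4-cyanophenyl amides does not carry over to the 4-propylphenyl amide, for which the comparison reads a 1.6-fold higher number from compound 1 to compound 4 (0.21 log units; within the scatter), while the 6-chloropyridin-3-yl amide stays apart from it, with a 2.7-fold higher number from compound 2 to compound 4 (0.43 log units; beyond the scatter) as the step. The compounds shown offer no evidence on why cyano and propyl read so alike at this position.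

From the compounds shown here alone, with only these two groups compared on this carbon, it remains open whether an amine, a carboxylic acid or a longer chain such as hexyl would move the number beyond the scatter in either direction. Going by these compounds, it is also open whether the close reading of cyano and propyl would hold on a different amide aryl ring, such as the chloropyridine of compound 2, or in another cell line.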